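The compounds below may be only part of what the source reports. "The series", "measured", "known", "first", "only" and "open" are said of these compounds alone.

In a functional assay on HT-29 cells (Homo sapiens) for inhibition, read by MTT assay, with a stated time of 3 days (on this read-out lower numbers stand for stronger inhibition and higher numbers for weaker inhibition), compound 1 `COCOc1cccc(/C=C/CCCOc2cc(/C=C\c3cc(OC)c(OC)c(OC)c3)ccc2OC)c1` gives 59000 nM, and compound 2 `COc1ccc(/C=C\c2cc(OC)c(OC)c(OC)c2)cc1OCCC/C=C/c1ccc(F)cc1` gives 98000 nM. These two numbers lie within the usual scatter of each other, so compound 2 cannot be ranked apart from compound 1. Compound 3 `COc1ccc(/C=C\c2cc(OC)c(OC)c(OC)c2)cc1OCCC/C=C/c1ccc(Br)cc1` has not yet been measured. It differs from compound 2 in one place: bromo in place of fluoro on an aromatic carbon, with bromo in place of fluoro on an aromatic carbon, para to a large group. Among the compounds with values here, no measured step makes this exact exchange. The closest evidence is a 1.7-fold higher number from compound 1 to compound 2 (0.22 log units; within the scatter), where 4-fluorophenyl took the place of 3-(methoxymethoxy)phenyl, and even that swap of a whole group stayed within the scatter. A step beyond the scatter is therefore not expected here. The expected change is a 1.2-fold lower number from compound 2 to compound 3 (0.09 log units; within the scatter). Compound 3 is estimated at 80000 nM, with an expected range of 35000 nM to 180000 nM.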

Compound 3, half-maximal inhibitory concentration: 11000 nM
Compound 3: the middle estimate sits 7.3-fold (0.86 log units) above what was measured; the measured number lies below the stated range.
By their numbers in this assay, from the lowest: compound 3; then compounds 1 and 2 (each within the scatter of the next).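

In this assay, the group on this aromatic carbon, para to a large group, turns out to matter, with an 8.9-fold lower number from compound 2 to compound 3 (0.95 log units; beyond the scatter) after only bromo took the place of fluoro. That exchange of one heavy atom for another, with no ring, hydrogen-bond donor, hydrogen-bond acceptor or net charge on either side, moves the number further than the earlier swap of a whole group, which gave a 1.7-fold higher number from compound 1 to compound 2 (0.22 log units; within the scatter) and stayed within the scatter. The 4-bromophenyl group also separates from the 3-(methoxymethoxy)phenyl group, giving a 5.4-fold lower number from compound 1 to compound 3 (0.73 log units; beyond the scatter) where the 4-fluorophenyl group did not.

No measurement at hand explains why bromo and fluoro differ here. As far as these compounds go, whether chloro, iodo or a methyl group at this same place would give a number nearer compound 2 or compound 3 remains open.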